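A sulfonyl group replaces a carbonyl-linked ring

The source may report more compounds than this note shows. Statements on the series, on what has been measured and on what is new or still open speak of the compounds shown alone.

Measured values (a functional assay on MCF7 cells (Homo sapiens) for antiproliferative activity, read by MTT assay, with a stated time of 48 h; on this read-out higher numbers stand for weaker inhibition and lower numbers for stronger inhibition):
Compound 1 (`O=C(Nc1cccc(/C=C/C(=O)c2nc3ccccc3[nH]2)c1)c1ccc(Br)cc1`) gives 7000 nM
Compound 2 (`O=C(Nc1cccc(/C=C/C(=O)c2nc3ccccc3[nH]2)c1)c1cc(Cl)cc(Cl)c1`) gives > 100000 nM

Compound 2 gives > 100000 nM in this assay as a limit, not a number. Compound 3 (`Cc1ccccc1S(=O)(=O)Nc1cccc(/C=C/C(=O)c2nc3ccccc3[nH]2)c1`) carries (2-methylphenyl)sulfonyl in place of (3,5-dichlorophenyl)carbonyl on a nitrogen on an aromatic ring. Within the data shown here, the only measured step (an at least 14-fold higher number from compound 1 to compound 2 (1.15 log units; beyond the scatter)) was large and changed the group on that same carbonyl carbon, though it tested no sulfonyl. Compound 1, with 7000 nM as a true number, shows that the shared core can give a measurable result. A large move towards a lower number is therefore expected (an at least 5.0-fold lower number from compound 2 to compound 3 (0.69 log units; beyond the scatter)). The expected value for compound 3 is 20000 nM (expected range 4000 nM to 100000 nM).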

Compound 3, half-maximal inhibitory concentration: 4130 nM
The estimate for compound 3 lay 4.8-fold (0.69 log units) above the measured number; measured number inside the range.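

With (2-methylphenyl)sulfonyl on the nitrogen on an aromatic ring, the shared core still gives a true number in this assay, and the comparison with the (4-bromophenyl)carbonyl group shows a 1.7-fold lower number from compound 1 to compound 3 (0.23 log units; within the scatter), so the two groups stand level. Against (3,5-dichlorophenyl)carbonyl, the same position shows an at least 24-fold lower number from compound 2 to compound 3 (1.38 log units; beyond the scatter). Compound 2 stands at a limit of the assay, not a number: the limit of > 100000 nM in this assay, at which 1 of the 3 values shown sits.

As far as these compounds go, how much of this belongs to the sulfonyl link and how much to the ring it carries stays open, since each pair changes both at once. A methylsulfonyl group or a free amine on that nitrogen would show whether any ring is needed there.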